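The source may hold more compounds than are shown below. What is called first, only, known or untested is meant among the compounds shown, and "the series" means these compounds.

Compound 1 `CC(C)NC1CC(=O)N(c2ccc(F)c(Cl)c2)C1OCC(F)(F)F` — 6610 nM
Compound 2 `CCc1ccc(N2C(=O)C=CC2OCC(F)(F)F)cc1` — 6510 nM

In a functional assay on HeLa cells (Homo sapiens) for inhibition (a lower number here means a stronger inhibitor, a higher number a weaker inhibitor), compound 2 gives 6510 nM, the smaller of the two numbers, while compound 1 gives 6610 nM, a gap within the scatter, so the two cannot be told apart. Compound 3 `CC(C)(C)c1ccc(N2C(=O)C=CC2OCC(F)(F)F)cc1` differs from compound 2 by tert-butyl in place of ethyl on an aromatic carbon. Among the compounds with values here, no step between measured compounds covers this change, so no direction is known; the expected step is none beyond the scatter. Compound 3 is estimated at 6000 nM, with a range of 2500 nM to 15000 nM, which amounts to an expected step of a 1.1-fold lower number from compound 2 to compound 3 (0.04 log units; within the scatter).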

Compound 3, half-maximal inhibitory concentration: 18100 nM
For compound 3 the middle estimate is 3.0-fold (0.48 log units) below the measured one; the whole stated range lies below it.
By their numbers in this assay, from the lowest: compounds 2 and 1 (each within the scatter of the next); then compound 3.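

In this assay, the place on the aromatic carbon para to a large group proves responsive to the group it carries: tert-butyl in place of ethyl gives a step beyond the scatter (a 2.8-fold higher number from compound 2 to compound 3 (0.44 log units; beyond the scatter)). Within the data shown here, the earlier compounds offered no step at all, so this is the first direction seen here, and it is towards weaker inhibition. Nothing at hand bears on why the number rises.

The compounds shown leave open whether a propyl chain would fall between ethyl and tert-butyl. They also leave open how an amine or a carboxylic acid at this place would compare.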